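Methyl for methoxy on the aryl amide of compound 2

This account rests on a few compounds, and the source may have more. Where it says the series, first, only, none or still open, it means among the compounds named here.

Measured compounds:
Compound 1, `N#Cc1cccc(C(=O)NCN2CCC(c3cccc[n+]3[O-])CC2)c1`: 69%
Compound 2, `COc1cc(C(=O)NCN2CCC(c3cccc[n+]3[O-])CC2)ccc1Cl`: 54%

In a functional assay on HEK293 cells for agonist activity at D(4) dopamine receptor (Homo sapiens), read by FLIPR (on this read-out lower numbers stand for smaller maximal responses and higher numbers for larger maximal responses), compound 1 reaches 69%. In this assay compound 2 reaches 54%, the lower of the two numbers and beyond the scatter from compound 1. Compound 3, `Cc1cc(C(=O)NCN2CCC(c3cccc[n+]3[O-])CC2)ccc1Cl`, is not yet measured; it differs from compound 2 in one place, (methyl in place of methoxy on an aromatic carbon), on the same core.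

Among the measured compounds shown here, the two measured compounds differ in several places at once, so no single step between them is available, and no measured pair shows what this particular change does. Compound 3 is therefore expected to stay close to compound 2, with a step of a number 4 percentage points higher from compound 2 to compound 3 (within the scatter) that is estimated not to reach beyond the usual scatter. In this assay compound 3 is estimated to reach 58%, within a range from 40% to 76%.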

Compound 3, largest response reached (reported as efficacy), in percent of the reference or control that the assay uses: 62%
Beside the measured number, compound 3's estimate is 4 percentage points below it; low and high end bracket the measured number.
By their numbers in this assay, from the lowest: compounds 2, 3 and 1 (each within the scatter of the next, the first and the last beyond it).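

In this assay, methyl in place of methoxy on this aromatic carbon, ortho to a chloro group, gives a number 8 percentage points higher from compound 2 to compound 3 (within the scatter) and so does not separate the two groups on this read-out. The swap of 3-cyanophenyl for 4-chloro-3-methylphenyl, read as a number 7 percentage points lower from compound 1 to compound 3 (within the scatter), leaves compound 3 within the scatter of both earlier compounds, although those two lie beyond the scatter of each other. No measurement at hand explains either step.

Going by these compounds, whether an ethyl group, a hydroxyl group or an amine on this same carbon would also stay within the scatter remains open. The compounds shown also leave open what the chloro group contributes, since no pair here changes it alone.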